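Phenyl in place of hydroxymethyl: the next antiproliferative reading

A few compounds are considered here, and "the series" means these few. Any claim that something is new, unique, unknown or untested is made for them only; others in the source may bear on it.

In a functional assay on SNB-19 cells (Homo sapiens) for antiproliferative activity, read by MTT assay (on this read-out lower numbers stand for stronger inhibition and higher numbers for weaker inhibition), compound 1 `O=C1C=C(N2CCCC2)C(=O)c2ccccc21` gives > 200000 nM, which is a limit and not a number (the limit of > 200000 nM in this assay, at which 1 of the 2 values shown sits). Within the data shown here, compound 2 `O=C1C=C(NCCO)C(=O)c2ccccc21` gives 108000 nM, the only true number so far, so it can be ranked against no other measured value. Among the measured compounds shown here, the one measured step, an at least 1.8-fold lower number from compound 1 to compound 2 (0.26 log units; that floor lies within the scatter), puts (2-hydroxyethyl)amino in place of pyrrolidin-1-yl on a double-bonded ring carbon. Compound 3 `O=C1C=C(NCc2ccccc2)C(=O)c2ccccc21` keeps the shared core and changes compound 2 on a saturated chain carbon bound to an amine nitrogen: phenyl in place of hydroxymethyl on a saturated chain carbon bound to an amine nitrogen. For the measured compounds named here, no measured step makes this exchange, so that single step offers only weak guidance. A moderate move to lower numbers in this assay is expected, though with wide uncertainty. The expected change is a 2.7-fold lower number from compound 2 to compound 3 (0.43 log units; beyond the scatter). For compound 3 the estimated value is 40000 nM, with an expected range from 10000 nM to 150000 nM.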

Compound 3, half-maximal inhibitory concentration: 80000 nM
Compound 3: the middle estimate sits 2.0-fold (0.30 log units) below what was measured; the measured number falls inside the stated range.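

At the position on a saturated chain carbon bound to an amine nitrogen, phenyl in place of hydroxymethyl gives a 1.4-fold lower number from compound 2 to compound 3 (0.13 log units; within the scatter) in this assay. A six-membered aromatic ring of carbon only thus enters and the hydrogen-bond donor and acceptor of hydroxymethyl leave, yet the readings of the two compounds stay within the scatter of each other, so this exchange shows no clear effect on the number at this place. Compound 1 remains a limit and not a number: the limit of > 200000 nM in this assay, at which 1 of the 3 values shown sits.

On these data alone, whether an amine or a carboxylic acid in place of phenyl on that saturated chain carbon would carry the number beyond the scatter stays open. So does the question of what a longer chain ending in phenyl would do in this assay.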